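The source may report more compounds than this note shows. Statements on the series, on what has been measured and on what is new or still open speak of the compounds shown alone.

Compound 3 `CCOCc1c(C)coc1-c1ccc2c(CC)cccc2c1OC` stands at the edge of what a functional assay on SK-BR-3 cells (Homo sapiens) for cytotoxicity, read by MTT assay, with a stated time of 72 h (on this read-out higher numbers stand for an effect only at larger amounts of compound and lower numbers for an effect already at smaller amounts), can report: its value of > 10 ug/mL is a limit of the assay, not a number. Compound 1 `CCCOC(=O)c1c(C)coc1-c1ccc2c(CC)cccc2c1OC` likewise gives only a limit, > 10 ug/mL. Compound 2 `CCc1cccc2c(OC)c(-c3occ(C)c3CO)ccc12`, by contrast, gives a number, 0.73 ug/mL. Two of the three values therefore rest on (the limit of > 10 ug/mL in this assay, at which 2 of the 3 values shown sit). The step of an at least 13-fold higher number from compound 2 to compound 3 (1.13 log units; beyond the scatter) is large, and so is an at least 13-fold lower number from compound 1 to compound 2 (1.13 log units; beyond the scatter); the step that the two limits leave unreadable from compound 1 to compound 3 cannot be read because both ends are limits.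

Compound 4 `CCc1cccc2c(OC)c(-c3occ(C)c3COCC(F)(F)F)ccc12` differs from compound 3 by trifluoromethyl in place of methyl on a saturated chain carbon bound to an oxygen on a saturated carbon. For the measured compounds named here, the one step that bears on this is the one from compound 2 to compound 3, where capping the hydroxyl with ethyl moved the value out to the limit; compound 4 keeps that ether cap and only exchanges methyl for trifluoromethyl on it. The expectation is that compound 4 stays at or near the limit, with an estimated value of 15 ug/mL, in the range 5 ug/mL to 40 ug/mL. The expected step that the limit leaves unreadable from compound 3 to compound 4 is thus not one that should be readable beyond the scatter.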

Compound 4, concentration for half-maximal effect: 5.3 ug/mL
The estimate for compound 4 lay 2.8-fold (0.45 log units) above the measured number; measured number inside the range.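

Among the ethers shown on this carbon, only compound 4 gives a number rather than a limit, so capping the hydroxyl of compound 2 now has a measured cost, a 7.3-fold higher number from compound 2 to compound 4 (0.86 log units; beyond the scatter). Exchanging methyl for trifluoromethyl on the cap gives an at least 1.8-fold lower number from compound 3 to compound 4 (0.27 log units; that floor lies within the scatter), and replacing the propoxycarbonyl group with (2,2,2-trifluoroethoxy)methyl gives an at least 1.8-fold lower number from compound 1 to compound 4 (0.27 log units; that floor lies within the scatter). Neither step is shown to lie beyond the scatter, because each starts from a compound that gives only a limit: the limit of > 10 ug/mL in this assay, at which 2 of the 4 values shown sit.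

From the compounds shown here alone, how far compound 3 lies past its limit stays open, and with it the true size of the trifluoromethyl change. Also open, going by these compounds, is how an amine or a carboxylic acid in place of the hydroxymethyl group, or a longer fluorinated chain on the ether, would read in this assay.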